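The compounds below may be only part of what the source reports. "The series", "measured", "known", "first", "only" and "open" are said of these compounds alone.

Measured in a functional assay on MOLT-4 cells (Homo sapiens) for antiproliferative activity, with a stated time of 48 h; on this read-out higher numbers stand for weaker inhibition and lower numbers for stronger inhibition:
compound 1 `C=C(Br)C(=O)Nc1ccc(C(=O)/C=C/c2ccc(OC)c(OC)c2OC)cc1`: 680 nM
compound 2 `COc1ccc(/C=C/C(=O)c2ccc(N)cc2)c(OC)c1`: 20000 nM

Compound 2 gives the higher of the two numbers, so it is the weaker inhibitor here, and its gap to compound 1 lies beyond the usual scatter. Compound 3 `COc1ccc(/C=C/C(=O)c2ccc(N)cc2)c(OC)c1OC` is compound 2 with a methoxy in place of hydrogen on an aromatic carbon, ortho to two methoxy groups (methoxy in place of hydrogen on an aromatic carbon). Among the compounds with values here, no two measured compounds differ in one place only, so the data offer no direct guide to this change. Compound 3 shares its methoxy groups with compound 1 680 nM, but compound 1 also differs elsewhere, which makes that value a weak guide. The estimated step of a 2.2-fold lower number from compound 2 to compound 3 (0.35 log units; beyond the scatter) is small and points toward stronger inhibition. For compound 3, the expected value is 9000 nM, with an estimated range from 3000 nM to 25000 nM.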

Compound 3, half-maximal inhibitory concentration: 10000 nM
Beside the measured number, compound 3's estimate is 1.1-fold (0.05 log units) below it; measured number inside the range.
By their numbers in this assay, from the lowest: compound 1; then compounds 3 and 2 (each within the scatter of the next).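

In this assay, putting a methoxy on the aromatic carbon ortho to two methoxy groups gives a 2.0-fold lower number from compound 2 to compound 3 (0.30 log units; within the scatter), so at this position the methoxy and the hydrogen cannot be told apart. Compound 3 also allows a comparison in one place with compound 1: hydrogen in place of (1-bromoethenyl)carbonyl on the nitrogen gives a 15-fold higher number from compound 1 to compound 3 (1.17 log units; beyond the scatter), so among these compounds the group on that nitrogen carries a far larger step than this methoxy does. No measurement here explains the size of either step.

On these data alone, whether an ethoxy or a chlorine atom at the same position would also stay within the scatter remains open. So does how much of the large step depends on the bromine, a question that a plain acryloyl or acetyl group on the nitrogen could address.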